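Shorter Chain and a Changed Amide End on a Triazole Series

The source may report more compounds than this note shows. Statements on the series, on what has been measured and on what is new or still open speak of the compounds shown alone.

Measured compounds:
compound 1 `O=C(CCCCCCCc1cn(-c2ccccc2-c2ccccc2)nn1)Nc1ccncc1` gives 32%
compound 2 `O=C(CCCCCCCc1cn(-c2ccccc2CO)nn1)NCc1cccnc1` gives 96%
compound 3 `O=C(CCCCCCCc1cn(-c2ccccc2Cc2ccccc2)nn1)NCc1cccnc1` gives 94%

In a functional assay on SH-SY5Y cells (Homo sapiens) for cytotoxicity, read by MTT assay, with a stated time of 48 h, tested at 10 uM (on this read-out lower numbers stand for a stronger effect and higher numbers for a weaker effect at the one concentration tested), compound 1 stands lowest of the three numbers, far apart from compound 3 and compound 2, both of which sit beyond the usual scatter above it. Compound 4 `O=C(CCCCCc1cn(-c2ccccc2-c2ccccc2)nn1)NCc1cccnc1` has not been measured. It differs from compound 1 in the following way: a group of 10 heavy atoms (7 carbon, 2 nitrogen, 1 oxygen; one six-membered aromatic ring with 1 hetero atom) in place of a group of 11 heavy atoms (8 carbon, 2 nitrogen, 1 oxygen; one six-membered aromatic ring with 1 hetero atom), on a saturated chain carbon, five bonds along the chain from an aromatic carbon.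

Within the data shown here, only one measured step exists, a number 2 percentage points lower from compound 2 to compound 3 (within the scatter), and it changes the group on the aromatic ring at the other end of the molecule, not the amide end or the chain length, so it does not bear on the change from compound 1 to compound 4. What can be said is that compound 2 and compound 3, which both carry the ((pyridin-3-yl)methyl)carbamoyl group, show weak effects, whereas compound 1, with a different amide end and the same aromatic group as compound 4, shows a strong one. Since the chain length and amide end change together, the outcome is uncertain, and a step upward in this assay is expected as a number 33 percentage points higher from compound 1 to compound 4 (beyond the scatter). Compound 4 is therefore estimated at 65%, within a range from 35% to 95%.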

Compound 4, a percentage reported as activity, at one concentration (the size of the read-out at that concentration, not a potency): 12.5%
Compound 4: the middle estimate sits 52.5 percentage points above what was measured; measured number outside the range, below it.
By their numbers in this assay, from the lowest: compound 4; then compound 1; then compounds 3 and 2 (each within the scatter of the next).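

In this assay, replacing the group on the saturated chain carbon, five bonds along the chain from an aromatic carbon, with ((pyridin-3-yl)methyl)carbamoyl gives a number 19.5 percentage points lower from compound 1 to compound 4 (beyond the scatter) and so moves the read-out modestly toward a stronger effect. Among these compounds, the only earlier step changed the aromatic ring at the other end of the molecule, so this is the first sign that the read-out responds to a change at this end while that aromatic group stays the same. Nothing measured here accounts for the size or direction of the step.

The chain length and the amide end change together in this single step, so the compounds shown cannot tell how much of it belongs to each. Keeping one fixed while varying the other would begin to separate them, for example by pairing the ((pyridin-3-yl)methyl)carbamoyl group with a longer chain, or by keeping the shorter chain and using a benzyl amide, which has a plain phenyl ring in place of the pyridine.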